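A few compounds are considered here, and "the series" means these few. Any claim that something is new, unique, unknown or untested is made for them only; others in the source may bear on it.

Measured compounds in an assay on CHO cells for displacement of a labelled ligand from Substance-P receptor (Homo sapiens); a higher number here means a weaker inhibitor, a lower number a stronger inhibitor:
Compound 1, `C[C@@H](O[C@@H]1CN(C=O)C[C@H]1c1ccc(F)cc1)c1cc(C(F)(F)F)cc(C(F)(F)F)c1`, gives 0.24 nM.
Compound 2, `CC(=O)N1CCC(C(=O)N2C[C@@H](O[C@H](C)c3cc(C(F)(F)F)cc(C(F)(F)F)c3)[C@H](c3ccc(F)cc3)C2)CC1`, gives 0.07 nM.
Compound 3, `Cc1cnc(C(=O)N2C[C@@H](O[C@H](C)c3cc(C(F)(F)F)cc(C(F)(F)F)c3)[C@H](c3ccc(F)cc3)C2)cn1`, gives 0.12 nM.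

All three share one core and differ only in the group on the carbonyl carbon attached to the ring nitrogen: hydrogen in compound 1, 1-acetylpiperidin-4-yl in compound 2, 5-methylpyrazin-2-yl in compound 3. Compound 3 stands second highest of the three numbers, with compound 2 nearest and compound 1 furthest, and neither gap reaches beyond the scatter.

Compound 4, `CCNC(=O)N1C[C@@H](O[C@H](C)c2cc(C(F)(F)F)cc(C(F)(F)F)c2)[C@H](c2ccc(F)cc2)C1`, is the next compound. The change from compound 3 is ethylamino in place of 5-methylpyrazin-2-yl on a carbonyl carbon, so the carbonyl now carries a short chain with a hydrogen-bond donor instead of an aromatic ring.

Every measured step concerns this same carbonyl carbon. Only a 3.4-fold lower number from compound 1 to compound 2 (0.54 log units; beyond the scatter) lies beyond the scatter, and it is modest; a 2.0-fold lower number from compound 1 to compound 3 (0.30 log units; within the scatter) and a 1.7-fold higher number from compound 2 to compound 3 (0.23 log units; within the scatter) stay within it. Three quite different groups at this position thus give numbers that hardly move, which suggests the position tolerates change. On that basis, compound 4 is expected to give about 0.15 nM, within 0.05 nM to 0.5 nM. The expected step is a 1.3-fold higher number from compound 3 to compound 4 (0.10 log units; within the scatter), meaning no movement beyond the scatter.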

Compound 4, half-maximal inhibitory concentration: 0.1 nM
Estimate against measurement, compound 4: 1.5-fold (0.18 log units) above; measured number inside the range.
By their numbers in this assay, from the lowest: compounds 2, 4, 3 and 1 (each within the scatter of the next, the first and the last beyond it).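

In this assay, the ringless ethylamino, with fewer heavy atoms than 5-methylpyrazin-2-yl and a hydrogen-bond donor where that group has none, stays within the scatter of it (a 1.2-fold lower number from compound 3 to compound 4 (0.08 log units; within the scatter)). It also stays within the scatter of 1-acetylpiperidin-4-yl (a 1.4-fold higher number from compound 2 to compound 4 (0.15 log units; within the scatter)), so among the compounds shown, a ring on this carbonyl carbon is not needed to keep the number this low, and a group joined to it through nitrogen serves as well as one joined through carbon. The step from the hydrogen of compound 1 reaches beyond the scatter but is modest (a 2.4-fold lower number from compound 1 to compound 4 (0.38 log units; beyond the scatter)), as it is for compound 2 and unlike compound 3, whose step from compound 1 stays within the scatter.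

No measurement shown explains why this position accepts such different groups. Also open, going by these compounds, is whether a longer chain such as hexylamino, a chain ending in a carboxylic acid, or a methoxy group on this carbonyl carbon would keep the number in the same narrow band.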